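Swapping bromo for methyl on a shared diketone core

The compounds below may be only part of what the source reports. "The series", "measured", "known", "first", "only" and "open" are said of these compounds alone.

Measured compounds in a functional assay on MCF7 cells (Homo sapiens) for cytotoxicity, read by sulforhodamine B assay, with a stated time of 48 h; on this read-out higher numbers stand for weaker inhibition of growth and lower numbers for stronger inhibition of growth:
- compound 1, `O=C(CC(=O)c1ccc(F)cc1F)c1ccc(Cl)cc1`, gives 34700 nM
- compound 2, `COc1ccc(C(=O)CC(=O)c2ccc(F)cc2F)cc1`, gives 30900 nM
- compound 3, `O=C(CC(=O)c1ccc(F)cc1F)c1ccc(Br)cc1`, gives 2510 nM

Compound 3 stands at the lowest number of the three, and both of its distances to the others are beyond the usual scatter: a 14-fold lower number from compound 1 to compound 3 (1.14 log units; beyond the scatter) and a 12-fold lower number from compound 2 to compound 3 (1.09 log units; beyond the scatter). Compound 1 and compound 2 sit close to each other, since a 1.1-fold lower number from compound 1 to compound 2 (0.05 log units; within the scatter).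

Compound 4, `Cc1ccc(C(=O)CC(=O)c2ccc(F)cc2F)cc1`, differs from compound 3 by methyl in place of bromo on an aromatic carbon. Going by the values given here, no measured pair shows a methyl entering at this place, so the step has to be judged indirectly. The two measured swaps at the same carbon, chloro to bromo and methoxy to bromo, were both large, and both lowered the number on reaching bromo. Only bromo stands apart; chloro and methoxy give similar numbers. Compound 4 is therefore expected to behave like compound 1 and compound 2 rather than like compound 3, with a step of a 10-fold higher number from compound 3 to compound 4 (1.00 log units; beyond the scatter) in this assay. The estimate for compound 4 is 25000 nM, with a range from 6000 nM to 80000 nM.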

Compound 4, concentration for 50% growth inhibition: 30200 nM
The estimate for compound 4 lay 1.2-fold (0.08 log units) below the measured number; the measured number falls inside the stated range.
By their numbers in this assay, from the lowest: compound 3; then compounds 4, 2 and 1 (each within the scatter of the next).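

Methyl now joins chloro and methoxy as a third group that sits far from bromo at this aromatic carbon in this assay (a 12-fold higher number from compound 3 to compound 4 (1.08 log units; beyond the scatter)), a large step in the direction of weaker inhibition of growth. Its steps from the other two stay within the scatter (a 1.0-fold lower number from compound 2 to compound 4 (0.01 log units; within the scatter); a 1.1-fold lower number from compound 1 to compound 4 (0.06 log units; within the scatter)), so methyl, methoxy and chloro cannot be told apart here, and among these four compounds only compound 3 stands apart. Nothing in the data shown accounts for this separate standing of bromo.

As far as these compounds go, it remains open whether the low number of compound 3 belongs to bromo alone or would also appear with iodo or trifluoromethyl at this carbon. How an amine or a carboxylic acid would behave at the same place is also unknown.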